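Trading a Dichlorophenyl for a Benzylcarbamoyl Group

The compounds below may be only part of what the source reports. "The series", "measured", "known", "first", "only" and "open" are said of these compounds alone.

Compound 1 `COc1ccc(-c2cnc3nc(N)nc(OC(C)C)c3n2)cc1`: in a functional assay on cells (T-cell, Homo sapiens) for inhibition (a lower number here means a stronger inhibitor, a higher number a weaker inhibitor), compound 1 reaches only the limit of the assay, > 10000 nM.
Compound 2 `COc1ccc(-c2cnc3nc(N)nc(N4CCN(c5cc(Cl)cc(Cl)c5)CC4)c3n2)cc1OC`: in this assay compound 2 gives 3400 nM.

Among the measured compounds shown here, compound 2 holds the only actual number in this set; the other entry is a limit, as the evidence records (the limit of > 10000 nM in this assay, at which 1 of the 2 values shown sits). So compound 2 is the sole anchor for any expectation, and it is a weak inhibitor by any measure.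

The next compound, compound 3 `COc1ccc(-c2cnc3nc(N)nc(N4CCN(C(=O)NCc5ccccc5)CC4)c3n2)cc1OC`, keeps everything in compound 2 except the group on the ring nitrogen: benzylcarbamoyl in place of 3,5-dichlorophenyl on an amine nitrogen in a ring. The outgoing group is a halogenated aromatic ring with no donor or acceptor; the incoming one brings a hydrogen-bond donor and acceptor and a double bond outside the aromatic rings.

For the measured compounds named here, no measured step between compounds is available to size this change. Since the series sits at the edge of detection, he expects a step from compound 2 to compound 3 of a 1.6-fold higher number from compound 2 to compound 3 (0.21 log units; within the scatter), toward weaker inhibition or none beyond the scatter. He therefore estimates compound 3 at 5500 nM, within a range of 1500 nM to 20000 nM, with a real chance that only a limit is reported.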

Compound 3, half-maximal inhibitory concentration: 18 nM
Compound 3: the middle estimate sits 310-fold (2.49 log units) above what was measured, and the stated range ends above it.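

Among the compounds shown here, replacing 3,5-dichlorophenyl with benzylcarbamoyl on the amine nitrogen in the ring gives a 190-fold lower number from compound 2 to compound 3 (2.28 log units; beyond the scatter) in this assay, the first measured step in the set, and it shows that the read-out responds strongly to the group at this position. Both groups carry one six-membered aromatic ring of carbon only, so the step goes with what else differs: the entering group brings a carbonyl, a hydrogen-bond donor and a hydrogen-bond acceptor, and the two chlorine atoms leave. As all of these differences arrive in a single change, their shares of the step cannot be separated, and no measured property of either compound accounts for the gain.

The compounds shown leave open which part of the benzylcarbamoyl group carries the effect, since a plain benzyl group or a benzoyl group on the same nitrogen would separate the aromatic ring, the carbonyl and the amide hydrogen. They also leave open whether chlorine on the ring of the benzylcarbamoyl group, or a longer chain between its nitrogen and that ring, would keep the inhibition seen with compound 3.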